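A few compounds are considered here, and "the series" means these few. Any claim that something is new, unique, unknown or untested is made for them only; others in the source may bear on it.

Compound 1 `Clc1cccc(-c2cnc(Nc3ccccc3)nc2-c2ccccc2)c1` gives 34% in an assay on CHO cells for displacement of a labelled ligand from adenosine receptor A1 (Homo sapiens), read by scintillation counting, with a stated time of 1 h, tested at 1 uM (a lower number here means less inhibition, a higher number more inhibition at the concentration tested (going by the name of the read-out)), and compound 2 `CC(C)Nc1ncc(-c2cccc(Cl)c2)c(-c2ccccc2)n1` gives 71%. Within the data shown here, the single measured step, a number 37 percentage points higher from compound 1 to compound 2 (beyond the scatter), leaves compound 2 as the higher of the two numbers. Compound 3 `CCCCNc1ncc(-c2cccc(Cl)c2)c(-c2ccccc2)n1` differs from compound 2 by butyl in place of isopropyl on a nitrogen on an aromatic ring. Among the measured compounds shown here, no measured step exchanges one alkyl for another, so the earlier step from phenyl to isopropyl is only a loose guide, and the expected change a number 6 percentage points lower from compound 2 to compound 3 (within the scatter) is none beyond the scatter. Compound 3 is therefore expected to give 65%, within a range of 40% to 85%.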

Compound 3, a percentage reported as inhibition, at one concentration (the size of the read-out at that concentration, not a potency): 56%
Compound 3: middle estimate off by 9 percentage points, on the high side; the range from low to high includes it.
By their numbers in this assay, from the lowest: compound 1; then compound 3; then compound 2.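

In this assay, the choice of alkyl on this nitrogen matters: butyl in place of isopropyl gives a number 15 percentage points lower from compound 2 to compound 3 (beyond the scatter). Butyl in place of phenyl still gives a number 22 percentage points higher from compound 1 to compound 3 (beyond the scatter), so both alkyl amines shown stand above the phenyl amine of compound 1. Nothing available explains the gap between butyl and isopropyl.

With only these two alkyl groups, the compounds shown cannot separate the effect of chain length from that of branching. Going by these compounds, how a cyclopropyl, an ethyl or a longer chain ending in an amine would read on this nitrogen remains open.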